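This account rests on a few compounds, and the source may have more. Where it says the series, first, only, none or still open, it means among the compounds named here.

Two compounds of a shared core, each carrying a triazole that bears a substituted phenyl ring, have been tested in a functional assay on SW480 cells (Homo sapiens) for cytotoxicity, read by MTT assay, with a stated time of 4 days; on this read-out higher numbers stand for weaker inhibition and lower numbers for stronger inhibition. Compound 1 `C=C1C[C@]23C[C@@]1(O)CC[C@H]2c1ccc(OS(=O)(=O)c2ccc(C)cc2)c(C)c1[C@@H]3Cn1cc(-c2ccc(C)cc2)nn1`, whose phenol is capped with a tosylate, gives only a limit in this assay, > 20000 nM, and not a number. Compound 2 `C=C1C[C@]23C[C@@]1(O)CC[C@H]2c1ccc(O)c(C)c1[C@@H]3Cn1cc(-c2ccc(C(F)(F)F)cc2)nn1`, with the free phenol and a trifluoromethyl on its phenyl ring, likewise gives only a limit, > 20000 nM. So compound 2 stands at the limit of > 20000 nM in this assay, at which 2 of the 2 values shown sit, with no value that can be placed above or below anything else.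

Compound 3 `C=C1C[C@]23C[C@@]1(O)CC[C@H]2c1ccc(O)c(C)c1[C@@H]3Cn1cc(-c2ccc(C)cc2)nn1` has not yet been measured. It differs from compound 2 in one place: methyl in place of trifluoromethyl on an aromatic carbon.

For the measured compounds named here, both measured compounds sit at the limit, so there is no measured step that would suggest a direction. The change from compound 2 to compound 3 is expected to give a step that the limit leaves unreadable from compound 2 to compound 3, that is, none beyond the scatter. Compound 3 is therefore estimated at 25000 nM, within a range of 8000 nM to 60000 nM, and most likely this assay will again report only a limit.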

Compound 3, half-maximal inhibitory concentration: > 20000 nM
Compound 3: only a limit was reported (the forecaster's own chance of this, stated with the estimate: 75%); the middle value lies beyond the limit too.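

No step can be read between compound 1, compound 2 and compound 3, since all three give only a limit and not a number: the limit of > 20000 nM in this assay, at which 3 of the 3 values shown sit. The compounds shown leave open whether trifluoromethyl, methyl or the tosylate cap makes any difference in this assay, and which change to the shared core would give a measurable value.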